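Swapping a distal hydrogen for trifluoromethyl on the urea series

The source may report more compounds than this note shows. Statements on the series, on what has been measured and on what is new or still open speak of the compounds shown alone.

Compound 1, `O=C(Nc1ccccc1)Nc1cccc(CNc2nccnc2Cl)c1`, is the weakest of the three measured ureas in a functional assay on T-24 cells (Homo sapiens) for antiproliferative activity, read by MTT assay, with a stated time of 48 h (on this read-out higher numbers stand for weaker inhibition and lower numbers for stronger inhibition), where compound 1 gives 19800 nM. Compound 2, `O=C(Nc1ccc(Cl)cc1)Nc1cccc(CNc2nccnc2Cl)c1`, gives 5470 nM, and compound 3, `O=C(Nc1cccc(CNc2nccnc2Cl)c1)Nc1ccc(Cl)c(Cl)c1`, gives 5210 nM. The two measured steps from compound 1 both replace a hydrogen on the outer phenyl ring: a 3.6-fold lower number from compound 1 to compound 2 (0.56 log units; beyond the scatter) and a 3.8-fold lower number from compound 1 to compound 3 (0.58 log units; beyond the scatter). The step of a 1.0-fold lower number from compound 2 to compound 3 (0.02 log units; within the scatter) shows that the second chloro adds nothing beyond the first.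

Compound 4, `O=C(Nc1cccc(CNc2nccnc2Cl)c1)Nc1cccc(C(F)(F)F)c1`, differs from compound 1 by trifluoromethyl in place of hydrogen on an aromatic carbon. Because the two analogous substitutions of this phenyl ring gave a 3.6-fold lower number from compound 1 to compound 2 (0.56 log units; beyond the scatter) and a 3.8-fold lower number from compound 1 to compound 3 (0.58 log units; beyond the scatter), a modest lowering of the number in this assay is expected, of similar size, though the new group sits meta to a large group rather than at the positions seen in compound 2 and compound 3. Compound 4 is therefore estimated at 6500 nM, with a likely range from 2800 nM to 15000 nM, meaning an expected step of a 3.0-fold lower number from compound 1 to compound 4 (0.48 log units; beyond the scatter).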

Compound 4, half-maximal inhibitory concentration: 5080 nM
Estimate against measurement, compound 4: 1.3-fold (0.11 log units) above; the measured number falls inside the stated range.
By their numbers in this assay, from the lowest: compounds 4, 3 and 2 (each within the scatter of the next); then compound 1.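

Trifluoromethyl on an aromatic carbon, meta to a large group, gives a 3.9-fold lower number from compound 1 to compound 4 (0.59 log units; beyond the scatter) in this assay, so a lower number is not tied to the chloro group or to the ring carbons substituted in compound 2 and compound 3. Among the four compounds shown, compound 1, with no substituent on its outer phenyl ring, has the highest number, and no substituted compound goes against this. The data at hand offer no measured basis for explaining this shift.

The compounds shown leave open whether a small group of another kind, such as an amine or a carboxylic acid, would also lower the number at this ring carbon. They also do not show what a chloro group would do at this same carbon, or whether trifluoromethyl would give a similar result elsewhere on the ring.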